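Carbamoyl in place of methoxyphenyl on the sulfanyl chain

A few compounds are considered here, and "the series" means these few. Any claim that something is new, unique, unknown or untested is made for them only; others in the source may bear on it.

Measured so far in a functional assay on PC-3 cells (Homo sapiens) for inhibition, read by MTT assay, with a stated time of 48 h; a higher number here means a weaker inhibitor, a lower number a stronger inhibitor:
- Compound 1, `CCSc1nnc(-c2cc(OC)c(OC)c(OC)c2)n1-c1ccc(OC)cc1`, gives 57700 nM.
- Compound 2, `COc1ccc(CSc2nnc(-c3cc(OC)c(OC)c(OC)c3)n2-c2ccc(OC)cc2)cc1`, gives 40300 nM.
- Compound 3, `COc1ccc(-n2c(SCC(=O)c3ccc4ccccc4c3)nnc2-c2cc(OC)c(OC)c(OC)c2)cc1`, reaches only the limit > 60000 nM, which is a limit of the assay and not a number.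

Compound 2 holds the lowest of the two numbers in this assay, and its nearest neighbour, compound 1, sits a 1.4-fold lower number from compound 1 to compound 2 (0.16 log units; within the scatter), so the two are not distinguishable. Compound 4, `COc1ccc(-n2c(SCC(=O)Nc3ccc(Cl)cc3)nnc2-c2cc(OC)c(OC)c(OC)c2)cc1`, differs from compound 2 in one place: (4-chlorophenyl)carbamoyl in place of 4-methoxyphenyl on a saturated chain carbon bound to a sulfur. The step that bears on it is the one in which the 4-methoxyphenyl of compound 2 was exchanged for a carbonyl-bearing group, an at least 1.4-fold higher number from compound 2 to compound 3 (0.17 log units; that floor lies within the scatter), where compound 3 sits at the limit (the limit of > 60000 nM in this assay, at which 1 of the 3 values shown sits). A small change, likely towards a higher number, is therefore expected for compound 4 in this assay, a 1.4-fold higher number from compound 2 to compound 4 (0.14 log units; within the scatter). Compound 4 is estimated at 55000 nM, with a range from 25000 nM to 120000 nM.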

Compound 4, half-maximal inhibitory concentration: 6290 nM
Estimate against measurement, compound 4: 8.7-fold (0.94 log units) above; measured number outside the range, below it.
By their numbers in this assay, from the lowest: compound 4; then compounds 2 and 1 (each within the scatter of the next). At a limit, above all of these: compound 3.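

In this assay, the group on the saturated chain carbon bound to a sulfur now moves the number beyond the scatter, which no earlier step had shown: a 6.4-fold lower number from compound 2 to compound 4 (0.81 log units; beyond the scatter), and a 9.2-fold lower number from compound 1 to compound 4 (0.96 log units; beyond the scatter). A carbonyl on this chain does not by itself set the outcome, since compound 3 and compound 4 both carry one and differ in what is bound to it, with an at least 9.5-fold lower number from compound 3 to compound 4 (0.97 log units; beyond the scatter). Compound 3 stands at a limit and not at a number, so that step gives only a floor: the limit of > 60000 nM in this assay, at which 1 of the 4 values shown sits.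

The compounds shown do not separate the amide hydrogen from the 4-chlorophenyl ring, as both enter together in compound 4. On these data alone, it also stays open whether a plain phenyl on the same carbamoyl, or a carboxylic acid in its place, would keep the lower number.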